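The source may report more compounds than this note shows. Statements on the series, on what has been measured and on what is new or still open speak of the compounds shown alone.

Among the measured compounds shown here, compound 1 `O=C(Nc1ccccc1O)C1CCc2ccccc2N1C(=O)c1ccc(Cl)cc1` is the only member of the series with a number in a functional assay on MDA-MB-231 cells (Homo sapiens) for cytotoxicity, read by sulforhodamine B assay, with a stated time of 72 h (on this read-out higher numbers stand for weaker inhibition of growth and lower numbers for stronger inhibition of growth), where compound 1 gives 19600 nM. Compound 2 `CCCC(=O)N1c2ccccc2CCC1C(=O)Nc1ccccc1C(F)(F)F` reaches only a limit of this assay, > 70000 nM, so its standing in the series is known only as a range; the evidence is the limit of > 70000 nM in this assay, at which 1 of the 2 values shown sits. Compound 3 `O=C(Nc1ccccc1C(F)(F)F)C1CCc2ccccc2N1C(=O)c1cccc(Cl)c1` carries the change (3-chlorophenyl in place of propyl on a carbonyl carbon), 3-chlorophenyl in place of propyl on a carbonyl carbon. For the measured compounds named here, since no measured pair spans this change, the step from compound 2 to compound 3 is expected as an at least 2.3-fold lower number from compound 2 to compound 3 (0.36 log units; beyond the scatter), toward stronger growth inhibition, and is uncertain. Compound 3 is estimated at 30000 nM, between 8000 nM and 100000 nM.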

Compound 3, concentration for 50% growth inhibition: 288 nM
For compound 3 the middle estimate is 100-fold (2.02 log units) above the measured one; the whole stated range lies above it.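

On a carbonyl carbon bonded to the amide-type nitrogen in a ring, 3-chlorophenyl in place of propyl gives an at least 240-fold lower number from compound 2 to compound 3 (2.38 log units; beyond the scatter) in this assay. This first step in the series shows that the group at this position can strongly change growth inhibition. Its true size remains open, because compound 2 stands at a limit of the assay: the limit of > 70000 nM in this assay, at which 1 of the 3 values shown sits.

Still open, as far as these compounds go, is whether the gain rests on the aromatic ring or on the chlorine; an unsubstituted phenyl or a cyclohexyl on the same carbonyl carbon would separate the two. The compounds shown also do not tell how far a longer chain at this position would go.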